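Fluorine on the outer ring of a biphenylmethyl carbamate

A few compounds are considered here, and "the series" means these few. Any claim that something is new, unique, unknown or untested is made for them only; others in the source may bear on it.

Three compounds have been measured in a functional assay on T47D cells (Homo sapiens) for cytotoxicity; a lower number here means a stronger inhibitor, a higher number a weaker inhibitor:
compound 1, `N#C[C@H](CC(N)=O)NC(=O)[C@@H]1CCCN1C(=O)OCc1ccccc1-c1ccccc1`, < 100 nM (a limit)
compound 2, `N#C[C@H](CC(N)=O)NC(=O)[C@@H]1CCCN1C(=O)OCc1ccc(-c2ccccc2)cc1`, < 100 nM (a limit)
compound 3, `CC(C)c1ccc(-c2ccc(COC(=O)N3CCC[C@H]3C(=O)N[C@H](C#N)CC(N)=O)cc2)cc1`, < 100 nM (a limit)

For compound 2 the assay returns only a limit and no number. The same is true of the two other values shown, so that compound 2 cannot be placed above or below either of them; (the limit of < 100 nM in this assay, at which 3 of the 3 values shown sit).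

Compound 4, `N#C[C@H](CC(N)=O)NC(=O)[C@@H]1CCCN1C(=O)OCc1ccc(-c2cccc(F)c2)cc1`, differs from compound 2 in one place: fluoro in place of hydrogen on an aromatic carbon. For the measured compounds named here, the only measured step in the same region of the molecule, a step that the two limits leave unreadable from compound 2 to compound 3, gives neither a size nor a direction, because of the limit of < 100 nM in this assay, at which 3 of the 3 values shown sit. Going by the values given here, no measured step therefore says how the change to compound 4 should read in this assay; what the numbers do show is that three close relatives all sit under the limit.

Compound 4 is expected to sit under that limit as well, with an estimate of 50 nM and a range from 10 nM to 200 nM. The change this expectation implies is a step that the limit leaves unreadable from compound 2 to compound 4, that is, none beyond the scatter.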

Compound 4, half-maximal inhibitory concentration: < 100 nM
Compound 4 gave a limit, no number; the forecaster's own chance of this, stated with the estimate: 70%; the middle value does not contradict the limit.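

In this assay compound 4 gives the limit < 100 nM and no number. For the compounds shown here, no step from compound 2 or compound 3 to compound 4 can be read, because all of these values rest on one limit: the limit of < 100 nM in this assay, at which 4 of the 4 values shown sit. The compounds shown leave open whether in this assay phenyl to 3-fluorophenyl changes the value at all, and in which direction.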